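Trimming a Dimethylamino Tail From a Sulfonamide

This account rests on a few compounds, and the source may have more. Where it says the series, first, only, none or still open, it means among the compounds named here.

Measured compounds:
compound 1, `Cc1ccc(S(=O)(=O)N(C)CC(C)C)cc1C#Cc1cc(Cl)ccc1OCC(=O)O`, 4.2 nM
compound 2, `CNS(=O)(=O)c1ccc(C)c(C#Cc2cc(Cl)ccc2OCC(=O)O)c1`, 10 nM
compound 3, `Cc1ccc(S(=O)(=O)N(C)CCN(C)C)cc1C#Cc1cc(Cl)ccc1OCC(=O)O`, 369 nM

These three share one core and differ only in what sits on the sulfonamide nitrogen. In an assay on CHO cells for displacement of a labelled ligand from prostaglandin D2 receptor 2 (Homo sapiens), read by scintillation counting (a higher number here means a weaker inhibitor, a lower number a stronger inhibitor), compound 3 gives the highest number of the three, so it is the weakest inhibitor among them: an 88-fold higher number from compound 1 to compound 3 (1.94 log units; beyond the scatter) and a 37-fold higher number from compound 2 to compound 3 (1.57 log units; beyond the scatter), both large steps. Compound 4, `Cc1ccc(S(=O)(=O)N(C)C)cc1C#Cc1cc(Cl)ccc1OCC(=O)O`, is not yet measured. It differs from compound 3 in one place: hydrogen in place of (dimethylamino)methyl on a saturated chain carbon bound to a sulfonamide nitrogen.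

The two large steps that reach compound 3 both bring in a dimethylamino-bearing chain, and both end in a much weaker inhibitor; compound 4 takes that chain away again, leaving only methyl groups on the nitrogen, as in compound 1 and compound 2, which differ from each other by a modest 2.4-fold higher number from compound 1 to compound 2 (0.38 log units; beyond the scatter). A large drop in the number is therefore expected, a 46-fold lower number from compound 3 to compound 4 (1.66 log units; beyond the scatter), landing near compound 1 and compound 2. The estimate for compound 4 is 8 nM, expected between 3 nM and 25 nM.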

Compound 4, inhibition constant: 5 nM
Compound 4: the middle estimate sits 1.6-fold (0.20 log units) above what was measured; measured number inside the range.
By their numbers in this assay, from the lowest: compounds 1, 4 and 2 (each within the scatter of the next, the first and the last beyond it); then compound 3.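

Removing the (dimethylamino)methyl group undoes almost all of the loss seen with compound 3 (a 74-fold lower number from compound 3 to compound 4 (1.87 log units; beyond the scatter)), so having two carbon groups on the sulfonamide nitrogen does not by itself weaken binding in this assay. Compound 4 stays within the scatter of both neighbours (a 2.0-fold lower number from compound 2 to compound 4 (0.30 log units; within the scatter) and a 1.2-fold higher number from compound 1 to compound 4 (0.08 log units; within the scatter)), which means that on this chain carbon, hydrogen and isopropyl cannot be told apart, while (dimethylamino)methyl costs a large step. Nothing measured here gives a reason for this contrast.

On these data alone, it remains open whether a hydroxyl or a carboxylic acid at the end of the chain would cost as much as the dimethylamino group. The compounds also do not show how a primary amine, or a longer chain carrying the dimethylamino group, would behave.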